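A few compounds are considered here, and "the series" means these few. Any claim that something is new, unique, unknown or untested is made for them only; others in the source may bear on it.

In a functional assay on L02 cells (Homo sapiens) for inhibition, read by MTT assay, with a stated time of 48 h (a higher number here means a weaker inhibitor, a lower number a stronger inhibitor), the measured compounds stand as follows.
Compound 1 `Cc1ccccc1NC(=O)/C=C/c1coc2cc(O)ccc2c1=O`: > 200000 nM, a limit of the assay.
Compound 2 `COc1ccc(CNC(=O)/C=C/c2coc3cc(OC)ccc3c2=O)cc1`: > 200000 nM, a limit of the assay.
Compound 3 `O=C(/C=C/c1coc2cc(O)ccc2c1=O)Nc1ccccc1`: > 200000 nM, a limit of the assay.

Compound 2 thus sits at the limit of > 200000 nM in this assay, at which 3 of the 3 values shown sit, and no number is known for it. Going by the values given here, the only step among the measured compounds, a step that the two limits leave unreadable from compound 1 to compound 3, runs between two limits and gives no size. Compound 4 `COc1ccc2c(=O)c(/C=C/C(=O)NCc3ccc(F)cc3F)coc2c1` differs from compound 2 by 2,4-difluorophenyl in place of 4-methoxyphenyl on a saturated chain carbon bound to an amide-type nitrogen. Among the compounds with values here, no measured step bears on this change, so no shift beyond the scatter can be read in this assay in either direction. The step that the limit leaves unreadable from compound 2 to compound 4 is expected to lie within the scatter. Compound 4 is expected to give 250000 nM, with a range from 100000 nM to 1000000 nM.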

Compound 4, half-maximal inhibitory concentration: > 200000 nM
Compound 4 was reported as a limit; the forecaster's own chance of this, stated with the estimate: 85%; the middle value is on the limit's open side.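

Going by these compounds alone, compound 2 and compound 4 each stand at a limit rather than a number, and no step between them can be read. The compounds shown leave open whether any change to them would give a measurable value in this assay.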